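The source may hold more compounds than are shown below. What is called first, only, known or untested is meant among the compounds shown, and "the series" means these compounds.

Measured so far in an assay (Cricetulus griseus) for inhibition of aldehyde dehydrogenase, mitochondrial (Homo sapiens); on this read-out higher numbers stand for weaker inhibition and lower numbers for stronger inhibition:
- compound 1 `O=c1c(-c2ccc(O)cc2)coc2cc(OCCOCCOCCO)ccc12`: 40 nM
- compound 2 `O=C(O)CCCCCCCOc1ccc2c(=O)c(-c3ccc(O)cc3)coc2c1`: 40 nM

Compound 2 stands level with compound 1 at the digits shown; the step of no change at the digits printed from compound 1 to compound 2 (within the scatter) lies within the scatter. Compound 3 `C=CCCCCOc1ccc2c(=O)c(-c3ccc(O)cc3)coc2c1` differs from compound 2 by vinyl in place of 3-carboxypropyl on a saturated chain carbon, four bonds along the chain from an oxygen on an aromatic ring: the chain is shortened and the carboxylic acid leaves. For the measured compounds named here, the only step that bears on it, no change at the digits printed from compound 1 to compound 2 (within the scatter), shows that exchanging the chain end left this assay unchanged, so for compound 3 a step of about a 1.3-fold higher number from compound 2 to compound 3 (0.10 log units; within the scatter) is expected, none beyond the scatter, with a somewhat wider range since no such shortening has been tested. Compound 3 is estimated at 50 nM, between 20 nM and 150 nM.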

Compound 3, half-maximal inhibitory concentration: 150 nM
For compound 3 the middle estimate is 3.0-fold (0.48 log units) below the measured one; low and high end bracket the measured number.
By their numbers in this assay, from the lowest: compounds 1 and 2 (each within the scatter of the next); then compound 3.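

In this assay this chain end cannot be exchanged freely: vinyl in place of 3-carboxypropyl gives a 3.8-fold higher number from compound 2 to compound 3 (0.57 log units; beyond the scatter) and but-3-en-1-yl in place of 2-(2-hydroxyethoxy)ethoxy gives a 3.8-fold higher number from compound 1 to compound 3 (0.57 log units; beyond the scatter) in the same direction. For the compounds shown here, the level values of compound 1 and compound 2 thus hold only for those two oxygen-bearing ends, and the all-carbon end of compound 3 is the first to move the number. No evidence at hand accounts for this shift.

Still open, on these data alone, is whether the higher number follows the departure of the carboxylic acid or the shortening, as compound 3 changes both at once. A longer chain ending in vinyl would separate the two.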